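Replacing one four-atom group with another on the core

This account rests on a few compounds, and the source may have more. Where it says the series, first, only, none or still open, it means among the compounds named here.

Compound 1 `N#Cc1cn(COCCO)c2ncnc(N)c12`: in an ADME assay (Fibroblast) for cytotoxicity, with Homo sapiens as the target (on this read-out higher numbers stand for weaker inhibition and lower numbers for stronger inhibition), compound 1 gives > 100000 nM, which is a limit of the assay and not a number.
Compound 2 `NC(=O)c1cn(COCCO)c2ncnc(N)c12`: in this assay compound 2 gives > 320000 nM, again a limit of the assay.
Compound 3 `NC(=NO)c1cn(COCCO)c2ncnc(N)c12`: in this assay compound 3 gives > 100000 nM, also a limit of the assay.

Compound 3 therefore stands at a limit, not at a measured number, and so do its two companions: two of the three values sit at the limit of > 100000 nM in this assay, at which 2 of the 3 values shown sit, and one at the limit of > 320000 nM in this assay, at which 1 of the 3 values shown sits. The steps between them cannot be read: a step that the two limits leave unreadable from compound 1 to compound 2, a step that the two limits leave unreadable from compound 1 to compound 3 and a step that the two limits leave unreadable from compound 2 to compound 3 are all hidden by the limits, so no size and no direction can be taken from them.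

Compound 4 `COC(=N)c1cn(COCCO)c2ncnc(N)c12` differs from compound 3 in one place: a group of 4 heavy atoms (2 carbon, 1 nitrogen, 1 oxygen; no ring) in place of a group of 4 heavy atoms (1 carbon, 2 nitrogen, 1 oxygen; no ring), on an aromatic carbon. Since every measured step is unreadable, no step beyond the scatter can be expected in this assay in either direction, and the step from compound 3 to compound 4 is estimated as a step that the limit leaves unreadable from compound 3 to compound 4. The estimate for compound 4 is 150000 nM, expected to lie between 30000 nM and 1000000 nM, most likely reported again only as a limit.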

Compound 4, half-maximal inhibitory concentration: > 100000 nM
Compound 4: no number, only a limit; the forecaster's own chance of this, stated with the estimate: 85%; the middle value lies beyond the limit too.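

Compound 4 also stands at a limit of the assay and gives no number, so no new step can be read from compound 1, compound 2 or compound 3 to compound 4: the limit of > 100000 nM in this assay, at which 3 of the 4 values shown sit. The compounds shown leave open whether changing the group on this aromatic carbon shifts the value in this assay at all.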